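The source may hold more compounds than are shown below. What is called first, only, known or untested is meant among the compounds shown, and "the series" means these compounds.

Of the compounds shown here, three sharing one core have been measured in a functional assay on MCF7 cells (Homo sapiens) for antiproliferative activity, read by sulforhodamine B assay, with a stated time of 48 h; on this read-out lower numbers stand for stronger inhibition and higher numbers for weaker inhibition. Compound 1 (`CCCN1CCN(c2ccc(S(=O)(=O)Oc3ccccc3OC)cc2)C1=O`) gives 13000 nM, compound 2 (`CCCN1CCN(c2ccc(S(=O)(=O)Oc3cccc(OC)c3)cc2)C1=O`) gives 6300 nM, and compound 3 (`CCCN1CCN(c2ccc(S(=O)(=O)Oc3ccc(C)cc3)cc2)C1=O`) gives 64000 nM, the highest number of the three. Compound 4 (`CCCN1CCN(c2ccc(S(=O)(=O)Oc3ccc(F)cc3)cc2)C1=O`) departs from compound 3 at a single place: fluoro in place of methyl on an aromatic carbon. It carries fluoro in place of methyl on an aromatic carbon, para to a large group, turning 4-methylphenyl into 4-fluorophenyl.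

Going by the values given here, no measured step makes this exact change. The closest evidence comes from swaps of the whole group on the oxygen: a 2.1-fold lower number from compound 1 to compound 2 (0.31 log units; beyond the scatter), a 4.9-fold higher number from compound 1 to compound 3 (0.69 log units; beyond the scatter) and a 10-fold higher number from compound 2 to compound 3 (1.01 log units; beyond the scatter). These show that the number responds to this group, from modest to large steps, but none of them involves fluoro, so they do not fix a direction. With compound 3 at 64000 nM, the top of the measured range, a move downward seems the likelier one. In this assay the expected change is a 2.1-fold lower number from compound 3 to compound 4 (0.33 log units; beyond the scatter), a modest step. For compound 4 the estimated value is 30000 nM, with an expected range of 9000 nM to 90000 nM.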

Compound 4, half-maximal inhibitory concentration: 33000 nM
Estimate against measurement, compound 4: 1.1-fold (0.04 log units) below, within the range that was stated.
By their numbers in this assay, from the lowest: compound 2; then compound 1; then compounds 4 and 3 (each within the scatter of the next).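

In this assay, fluoro in place of methyl on this aromatic carbon gives a step within the scatter (a 1.9-fold lower number from compound 3 to compound 4 (0.29 log units; within the scatter)), so this position does not separate the two groups. The earlier compounds shown here showed that the number responds to the group on the oxygen, and compound 4 now shows that 4-fluorophenyl, like 4-methylphenyl, stays on the weak side of both methoxyphenyl groups (a 5.2-fold higher number from compound 2 to compound 4 (0.72 log units; beyond the scatter); a 2.5-fold higher number from compound 1 to compound 4 (0.40 log units; beyond the scatter)). Nothing shown here bears on why this swap changes so little.

Going by these compounds, whether a chloro, a hydroxyl or an amine on this aromatic carbon would also stay in this range remains open. Also open, on these data alone, is whether a methoxy group on this same carbon would bring the number down toward that of compound 2.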